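From an oxazole to an isopropyl isoxazole on the amine

The source may hold more compounds than are shown below. What is called first, only, known or untested is meant among the compounds shown, and "the series" means these compounds.

Compound 2 `Nc1nc(NCc2ncco2)c2c(ccn2Cc2ccccn2)n1` is the starting point. In an ADME assay on HEK293 cells (Homo sapiens) for cytotoxicity, read by ATP content, with a stated time of 6 h (a higher number here means that more compound is tolerated, a lower number that less compound is tolerated), compound 2 gives > 24000 nM, which is a limit of the assay and not a number. Within the data shown here, its one measured neighbour is compound 1 `Cc1ccc(CNc2nc(N)nc3ccn(Cc4ccccn4)c23)nc1`, which differs from it in a single place. In this assay compound 1 gives > 24000 nM, again a limit of the assay. Among the measured compounds shown here, the only measured step, a step that the two limits leave unreadable from compound 1 to compound 2, thus joins two values that both rest at the limit of > 24000 nM in this assay, at which 2 of the 2 values shown sit, and its size gives no guidance.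

Compound 3 `CC(C)c1cc(CNc2nc(N)nc3ccn(Cc4ccccn4)c23)no1` has not yet been measured. It differs from compound 2 in one respect: 5-isopropyl-1,2-oxazol-3-yl in place of 1,3-oxazol-2-yl on a saturated chain carbon bound to a nitrogen on an aromatic ring. For the measured compounds named here, no measured step bears on this change, since the one step available is unreadable and both measured values lie at the limit. With nothing pointing in either direction, the step from compound 2 to compound 3 is expected to be a step that the limit leaves unreadable from compound 2 to compound 3, that is, nothing beyond the scatter, and most probably another limit. The estimate for compound 3 in this assay is therefore 30000 nM, within a range from 12000 nM to 80000 nM.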

Compound 3, half-maximal cytotoxic concentration: > 24000 nM
Compound 3 ended at the assay's limit (the forecaster's own chance of this, stated with the estimate: 80%); the middle value does not contradict the limit.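

In this assay compound 3 gives > 24000 nM, which is a limit of the assay and not a number. No step among compound 1, compound 2 and compound 3 can be read, because all of them rest at the same limit: the limit of > 24000 nM in this assay, at which 3 of the 3 values shown sit.

The compounds shown leave open whether the groups on the saturated chain carbon make any difference in this assay.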